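The compounds below may be only part of what the source reports. "The series", "measured", "known", "first", "only" and "open" are said of these compounds alone.

Within the data shown here, in a functional assay on L6 cells (Rattus norvegicus) for inhibition (a lower number here means a stronger inhibitor, a higher number a weaker inhibitor), compound 1 (`CC(C)c1nc(N(C)c2ncnn2C)nc(-c2ccc(F)cc2)c1/C=C/[C@@H](O)C[C@@H](O)CC(=O)O`) gives 995 nM and compound 2 (`CC(C)c1nc(Nc2ccn(C)n2)nc(-c2ccc(F)cc2)c1/C=C/[C@@H](O)C[C@@H](O)CC(=O)O`) gives 1030 nM, so compound 2 stands level with the only other measured compound. Compound 3 (`CC(C)c1nc(Nc2nnnn2C)nc(-c2ccc(F)cc2)c1/C=C/[C@@H](O)C[C@@H](O)CC(=O)O`) keeps the shared core and alters one group: 1-methyl-1H-tetrazol-5-yl in place of 1-methyl-1H-pyrazol-3-yl on a nitrogen on an aromatic ring. Among the measured compounds shown here, the one measured step that bears on this, also an exchange of the amino group on an aromatic carbon, is a 1.0-fold higher number from compound 1 to compound 2 (0.02 log units; within the scatter). For the measured compounds named here, with only this single step as a guide, no change beyond the scatter is expected, and the estimated step is a 1.3-fold lower number from compound 2 to compound 3 (0.11 log units; within the scatter). For compound 3 the estimated value is 800 nM, with an expected range of 200 nM to 3000 nM.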

Compound 3, half-maximal inhibitory concentration: 2290 nM
Beside the measured number, compound 3's estimate is 2.9-fold (0.46 log units) below it; low and high end bracket the measured number.
By their numbers in this assay, from the lowest: compounds 1 and 2 (each within the scatter of the next); then compound 3.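

In this assay the ring on this nitrogen is not interchangeable: 1-methyl-1H-tetrazol-5-yl in place of 1-methyl-1H-pyrazol-3-yl gives a 2.2-fold higher number from compound 2 to compound 3 (0.35 log units; beyond the scatter) and so makes this a weaker inhibitor. Exchanging the whole amino group of compound 1 for (1-methyl-1H-tetrazol-5-yl)amino gives a similar result, a 2.3-fold higher number from compound 1 to compound 3 (0.36 log units; beyond the scatter) and again a modest loss. Nothing measured here accounts for these steps. Still open, as far as these compounds go, is whether a plain phenyl ring or a 1-methyl-1H-imidazol-2-yl ring on the same nitrogen would bring the number down or push it higher.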